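Moving the methoxy group in a cytotoxicity series

The source may hold more compounds than are shown below. What is called first, only, known or untested is meant among the compounds shown, and "the series" means these compounds.

In an ADME assay on Vero cells (Chlorocebus sabaeus) for cytotoxicity, read by MTT assay, with a stated time of 72 h (a lower number here means that less compound is tolerated, a higher number that more compound is tolerated), compound 1 `COC(=O)c1cc(-c2cccc(NC(=O)c3ccc(OCc4ccc(Cl)cc4)cc3)c2)on1` gives > 80 ug/mL, which is a limit of the assay rather than a number. Compound 2 `COC(=O)c1cc(-c2cccc(NC(=O)c3ccc(/C=C/C(=O)c4ccccc4)cc3)c2)on1` gives > 50 ug/mL in this assay, again a limit. Compound 3 `COC(=O)c1cc(-c2cccc(NC(=O)c3ccc(/C=C/C(=O)c4ccc(OC)cc4)cc3)c2)on1` gives > 10 ug/mL in this assay, once more a limit and not a number. All three values are limits, so none of the steps among them can be read: a step that the two limits leave unreadable from compound 1 to compound 2, a step that the two limits leave unreadable from compound 1 to compound 3 and a step that the two limits leave unreadable from compound 2 to compound 3 all remain of unknown size. Compound 3 therefore stands at a limit, and its two neighbours also sit at limits (the limit of > 10 ug/mL in this assay, at which 1 of the 3 values shown sits, (the limit of > 50 ug/mL in this assay, at which 1 of the 3 values shown sits), (the limit of > 80 ug/mL in this assay, at which 1 of the 3 values shown sits)), so no ordering of the three can be drawn from the numbers.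

Compound 4 `COC(=O)c1cc(-c2cccc(NC(=O)c3ccc(/C=C/C(=O)c4cccc(OC)c4)cc3)c2)on1` differs from compound 3 in one place: 3-methoxyphenyl in place of 4-methoxyphenyl on a carbonyl carbon. Within the data shown here, no measured step bears on this change in a readable way, and the atoms of the two compounds are the same, only joined differently. Compound 4 is therefore expected to tolerate a similar amount, estimated at 40 ug/mL (range 10 ug/mL to 160 ug/mL), most likely reported again as a limit. This estimate means a step that the limit leaves unreadable from compound 3 to compound 4, expected to be none beyond the scatter.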

Compound 4, half-maximal cytotoxic concentration: > 100 ug/mL
Compound 4: only a limit was reported (the forecaster's own chance of this, stated with the estimate: 70%); at least 2.5-fold (0.39 log units) between middle value and limit.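

In this assay compound 4 gives > 100 ug/mL, a limit of the assay and not a number. Compound 3 gives > 10 ug/mL, also a limit. Among these compounds, no step from compound 1, compound 2 or compound 3 to compound 4 can therefore be read. The compounds shown leave open whether 3-methoxyphenyl in place of 4-methoxyphenyl changes how much compound is tolerated.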